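A few compounds are considered here, and "the series" means these few. Any claim that something is new, unique, unknown or untested is made for them only; others in the source may bear on it.

Measured so far:
- compound 1, `CCC[C@@H](OC(C)=O)C1=C(Br)/C(=C/Br)OC1=O`: 1.7 ug/mL
- compound 2, `CCC[C@@H](OC(C)=O)C1=C(Br)C(=C(Br)Br)OC1=O`: 1.1 ug/mL
- compound 3, `CCC[C@@H](OC(C)=O)C1=C(Br)[C@@](OC)(C(Br)Br)OC1=O`: > 20 ug/mL

Of the compounds shown here, three sharing one core have been tested in a functional assay on Lu1 cells (Homo sapiens) for cytotoxicity; on this read-out lower numbers stand for an effect already at smaller amounts and higher numbers for an effect only at larger amounts of compound. Compound 1 gives 1.7 ug/mL and stands at the higher of the two numbers reported, with compound 2 nearest at 1.1 ug/mL; that gap lies within the usual scatter, so the two are read as alike. For compound 3 the assay reports only a limit, > 20 ug/mL, and not a number (the limit of > 20 ug/mL in this assay, at which 1 of the 3 values shown sits).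

The unmeasured compound 4, `CCC[C@@H](O)C1=C(Br)/C(=C/Br)OC1=O`, differs from compound 1 in a single place: hydrogen in place of acetyl on an oxygen on a saturated carbon. For the measured compounds named here, no measured pair shows this exchange of acetyl for hydrogen, so there is no direct precedent for its size. The expectation is that the step in this assay will be small, if anything toward a slightly higher number, and may well stay within the scatter. Compound 4 is therefore estimated at 2.5 ug/mL, with a range from 1 ug/mL to 8 ug/mL, which means a step of a 1.5-fold higher number from compound 1 to compound 4 (0.17 log units; within the scatter).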

Compound 4, concentration for half-maximal effect: 0.3 ug/mL
The estimate for compound 4 lay 8.3-fold (0.92 log units) above the measured number; the whole stated range lies above it.
By their numbers in this assay, from the lowest: compound 4; then compounds 2 and 1 (each within the scatter of the next). At a limit, above all of these: compound 3.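

In this assay, the exchange of acetoxy to hydroxy gives a 5.7-fold lower number from compound 1 to compound 4 (0.75 log units; beyond the scatter), a modest change but one that clearly exceeds the usual scatter. The earlier compounds shown here all carried the acetyl group, so they could not show whether this oxygen matters; this pair shows that the read-out responds to a change at this place, and that the effect does not depend on the acetyl group being present. This is a single pair on a single core, and nothing measured here explains the direction or size of the step.

Going by these compounds, whether removing the acetyl group would have a similar effect on the core of compound 2 remains open. So does the outcome of placing a methyl ether, a longer acyl group such as butyryl, or an amine at this position.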